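A few compounds are considered here, and "the series" means these few. Any claim that something is new, unique, unknown or untested is made for them only; others in the source may bear on it.

Compound 1 `CC1=CC[C@@]2(O)[C@H](C)CC[C@@H](C(C)C)[C@@H]2C1=O` in a functional assay on HCT-8 cells (Homo sapiens) for cytotoxicity, read by MTT assay (on this read-out lower numbers stand for stronger inhibition and higher numbers for weaker inhibition), gives only the assay's limit, > 10 ug/mL.
Compound 2 `CC1=CC[C@]2(O)[C@@H]([C@@H]1O)[C@H](C(C)C)CC[C@H]2C` in this assay gives only the assay's limit, > 10 ug/mL.

Compound 2 thus stands at the limit of > 10 ug/mL in this assay, at which 2 of the 2 values shown sit, and no number is known for it. Compound 3 `CC1=CC[C@]2(O)[C@@H]([C@H]1O)[C@H](C(C)C)CC[C@H]2C` differs from it as follows: the two compounds have the same atoms and bonds and differ only in configuration as drawn: 1 of 5 stereo elements differ; a stereocentre at a saturated ring carbon is drawn S in compound 2 and R in compound 3. For the measured compounds named here, no measured step of this kind exists here, so the expectation for the change from compound 2 to compound 3 is a step that the limit leaves unreadable from compound 2 to compound 3, that is, none beyond the scatter. Compound 3 is therefore estimated at 15 ug/mL, between 5 ug/mL and 50 ug/mL, and will most likely be reported only as a limit.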

Compound 3, half-maximal inhibitory concentration: > 10 ug/mL
Compound 3 was reported as a limit; the forecaster's own chance of this, stated with the estimate: 75%; the middle value is on the limit's open side.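

For the compounds shown here, compound 2 and compound 3 each give only a limit in this assay, so no step between them can be read. Going by these compounds, whether the configuration at that saturated ring carbon matters in this assay remains open.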